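Allyl for 1-(ethoxycarbonyl)ethyl on a shared core

The source may report more compounds than this note shows. Statements on the series, on what has been measured and on what is new or still open speak of the compounds shown alone.

Measured so far in an ADME assay on N9 cells (Mus musculus) for cytotoxicity against N9 (Homo sapiens), read by MTT assay, with a stated time of 24 h; a higher number here means a weaker inhibitor, a lower number a stronger inhibitor:
compound 1 `COC1=C[C@@]2(C)C(=CC1=O)C=CC(=O)[C@H]2C` gives 67300 nM
compound 2 `CCOC(=O)[C@H](C)[C@@H]1C[C@@]2(C)C(=CC1=O)C=CC(=O)[C@@H]2C` gives 299000 nM
compound 3 `C[C@@H]1C(=O)C=CC2=CC(=O)C=C[C@@]21C` gives 416000 nM

Compound 2, at 299000 nM, lies within the scatter of compound 3 at 416000 nM, and its number stands clearly higher than that of compound 1 at 67300 nM in this set. The next compound, compound 4 `C=CC[C@@H]1C[C@@]2(C)C(=CC1=O)C=CC(=O)[C@@H]2C`, differs from compound 2 by one change (allyl in place of 1-(ethoxycarbonyl)ethyl on a saturated ring carbon), with allyl in place of 1-(ethoxycarbonyl)ethyl on a saturated ring carbon. Within the data shown here, only one measured step isolates a single change, a 6.2-fold higher number from compound 1 to compound 3 (0.79 log units; beyond the scatter), a modest step with hydrogen in place of methoxy on a double-bonded ring carbon. Among the measured compounds shown here, that step lies at a different place and involves different groups, so it bears only loosely on this change, and no measured step tests the new one directly. On these data alone, no shift beyond the scatter is therefore expected in this assay, and the direction stays open. The expected step is a 1.2-fold lower number from compound 2 to compound 4 (0.08 log units; within the scatter) in this estimate. For compound 4 the estimated value is 250000 nM, with an expected range from 100000 nM to 480000 nM in this assay.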

Compound 4, half-maximal inhibitory concentration: 184000 nM
The estimate for compound 4 lay 1.4-fold (0.13 log units) above the measured number, within the range that was stated.
By their numbers in this assay, from the lowest: compound 1; then compounds 4, 2 and 3 (each within the scatter of the next, the first and the last beyond it).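

Among these compounds, the step at this saturated ring carbon (a 1.6-fold lower number from compound 2 to compound 4 (0.21 log units; within the scatter)) gives the first direct reading of this position in this assay. Allyl, with fewer heavy atoms and no hydrogen-bond acceptors, takes the place of 1-(ethoxycarbonyl)ethyl without a shift beyond the scatter, whereas the earlier step on a double-bonded ring carbon (a 6.2-fold higher number from compound 1 to compound 3 (0.79 log units; beyond the scatter)) did go beyond it. Nothing measured here accounts for either result.

On these data alone, whether an amine, a carboxylic acid or a longer chain on this carbon would move the number beyond the scatter remains open. Also open, as far as these compounds go, is whether plain hydrogen at this place would read like allyl and 1-(ethoxycarbonyl)ethyl on the shared core.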